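Three Measured Compounds and One Still Waiting

A few compounds are considered here, and "the series" means these few. Any claim that something is new, unique, unknown or untested is made for them only; others in the source may bear on it.

In an assay on cells (Hepatocyte) for inhibition of glucokinase regulatory protein (Mus musculus), with stated times of 20 min and 40 min (a lower number here means that less compound is needed, a higher number that more compound is needed for the effect), compound 3 `CC#C[C@H]1CN(S(=O)(=O)c2ccc(N)nc2)CCN1c1ccc(S(=N)(=O)C2CC2)cc1` gives 208 nM, the lowest of the two numbers shown. Among the measured compounds shown here, compound 1 `CC#C[C@H]1CN(S(=O)(=O)c2ccc(N)nc2)CCN1c1ccc(C(=O)NC)cc1` gives 4050 nM in this assay, and the step of a 19-fold lower number from compound 1 to compound 3 (1.29 log units; beyond the scatter) is the only measured step between two compounds that differ in one place. Compound 2 `CC#C[C@H]1CN(S(=O)(=O)c2ccc(N)nc2)CCN1c1ncc(C(O)(C(F)(F)F)C(F)(F)F)s1` reaches only the limit of this assay, > 12500 nM, so no number is known for it (the limit of > 12500 nM in this assay, at which 1 of the 3 values shown sits).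

Compound 4 `CC#C[C@H]1CN(S(=O)(=O)c2ccc(N)nc2)CCN1c1ccc([C@](O)(CO)C(F)(F)F)cc1` has not yet been measured. It differs from compound 3 in one place: a group of 8 heavy atoms (3 carbon, 2 oxygen, 3 fluorine; no ring) in place of a group of 6 heavy atoms (3 carbon, 1 nitrogen, 1 oxygen, 1 sulfur; one three-membered non-aromatic ring of carbon only), on an aromatic carbon. The measured step at this same aromatic carbon, a 19-fold lower number from compound 1 to compound 3 (1.29 log units; beyond the scatter), was large, so a change of group at this position can move the number far in this assay. For the measured compounds named here, the 1,2-dihydroxy-1-(trifluoromethyl)ethyl group of compound 4 appears in no measured compound, so the direction rests on that single step and on the high number of compound 1. Compound 4 is therefore expected to give about 900 nM in this assay, within a range of 200 nM to 4000 nM. The estimate means an expected step of a 4.3-fold higher number from compound 3 to compound 4 (0.64 log units; beyond the scatter).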

Compound 4, half-maximal effective concentration: 98 nM
The estimate for compound 4 lay 9.2-fold (0.96 log units) above the measured number, outside the stated range (below it).
By their numbers in this assay, from the lowest: compound 4; then compound 3; then compound 1. At a limit, above all of these: compound 2.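

In this assay the new result shows that this position, on an aromatic carbon para to a large group, does not need the sulfur-bearing, ring-containing group of compound 3 for a low number: there is a 2.1-fold lower number from compound 3 to compound 4 (0.33 log units; beyond the scatter), and the acyclic 1,2-dihydroxy-1-(trifluoromethyl)ethyl group goes further still, with a 41-fold lower number from compound 1 to compound 4 (1.62 log units; beyond the scatter). Before this, the position rested on a single step, whereas two groups with different atoms and no shared ring now both stand well under the methylcarbamoyl group of compound 1, and the step between them, though modest, is printed as beyond the scatter. The compounds shown give no measured property that would explain why this group gives the lowest number of the series.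

The compounds shown leave open which part of the 1,2-dihydroxy-1-(trifluoromethyl)ethyl group carries the effect, since no compound shows it with a methyl in place of the trifluoromethyl, or with a plain methyl in place of the hydroxymethyl arm. As far as these compounds go, it also remains open what the opposite configuration at its stereocentre would give, and whether a carboxylic acid or an amine at this position would keep the number this low.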